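The compounds below may be only part of what the source reports. "The series", "measured", "known", "first", "only" and "open" are said of these compounds alone.

Compounds measured in a functional assay on CHO cells for antagonist activity at 5-hydroxytryptamine receptor 6 (Homo sapiens), read by FLIPR; a lower number here means a stronger inhibitor, a higher number a weaker inhibitor:
compound 1 `CN1CCC(N(C)C(=O)C2CN(S(=O)(=O)c3cccc4c(Cl)cccc34)c3ccccc32)CC1` 5.01 nM
compound 2 `CN1CCC(N(C)C(=O)C2CN(S(=O)(=O)c3ccc4c(c3)OCCO4)c3ccccc32)CC1` 50.1 nM

Among the compounds with values here, compound 2 gives the highest of the two numbers in this assay; the single measured step, a 10-fold higher number from compound 1 to compound 2 (1.00 log units; beyond the scatter), separates it from the only other compound. Compound 3 `CN1CCC(N(C)C(=O)C2CN(S(=O)(=O)c3cccc4nsnc34)c3ccccc32)CC1` arises from compound 2 by a group of 9 heavy atoms (6 carbon, 2 nitrogen, 1 sulfur; one five-membered aromatic ring with 3 hetero atoms, one six-membered aromatic ring of carbon only) in place of a group of 10 heavy atoms (8 carbon, 2 oxygen; one six-membered non-aromatic ring with 2 hetero atoms, one six-membered aromatic ring of carbon only), on a sulfonyl sulfur. That one step bears on this position, since it also exchanged the group on the sulfonyl sulfur, and it was modest but beyond the scatter. Compound 3 is therefore expected to move back toward compound 1 by an estimated 3.3-fold lower number from compound 2 to compound 3 (0.52 log units; beyond the scatter). The estimate for compound 3 is 15 nM, with a range of 3 nM to 80 nM.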

Compound 3, inhibition constant: 126 nM
The estimate for compound 3 lay 8.4-fold (0.92 log units) below the measured number; the whole stated range lies below it.
By their numbers in this assay, from the lowest: compound 1; then compound 2; then compound 3.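

In this assay, the new group on the sulfonyl sulfur does not move the number back toward compound 1 but further from it (a 2.5-fold higher number from compound 2 to compound 3 (0.40 log units; beyond the scatter)), and the distance from the chlorinated group is large (a 25-fold higher number from compound 1 to compound 3 (1.40 log units; beyond the scatter)). A group with two aromatic rings at this place therefore does not by itself give the low number of compound 1. Nothing measured here accounts for either step.

On these data alone, what remains open is how much of the low number of compound 1 rests on its chlorine rather than on its two carbon rings. Plain naphthalen-1-yl, or a bromine in place of the chlorine, would separate the two.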